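A few compounds are considered here, and "the series" means these few. Any claim that something is new, unique, unknown or untested is made for them only; others in the source may bear on it.

Three compounds built on one shared core have so far been examined in an assay on HEK293 cells for inhibition of Voltage-dependent T-type calcium channel subunit alpha-1G (Homo sapiens), read by fluorescence, tested at 10 uM; on this read-out lower numbers stand for less inhibition and higher numbers for more inhibition at the one concentration tested (going by the name of the read-out). Compound 1 `CCCc1nc(-c2ccccc2)c(CNCCN2CCN(C(c3ccccc3)c3ccccc3)CC2)o1` gives 71.9%. Compound 2 `CCCc1nc(-c2ccccc2)c(CNCCCN2CCN(c3cccc(C)c3)CC2)o1` gives 47.8%, the second highest of the three numbers; compound 3 `CCCc1nc(-c2ccccc2)c(CNCCN2CCN(c3cccc(OC)c3)CC2)o1` gives 40.2%, which lies within the scatter of compound 2, whereas compound 1 stands beyond the scatter on the higher side. Compound 4 `CCCc1nc(-c2ccccc2)c(CNCCCN2CCN(c3ccc(C)c(C)c3)CC2)o1` remains to be measured in this assay. It differs from compound 2 by methyl in place of hydrogen on an aromatic carbon. Within the data shown here, no measured pair shows this change, so the step is expected to be small, not beyond the scatter in either direction. The step this estimate means is a number 2.2 percentage points higher from compound 2 to compound 4 (within the scatter). Compound 4 is therefore expected to give 50%, in a range from 30% to 70%.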

Compound 4, a percentage reported as inhibition, at one concentration (the size of the read-out at that concentration, not a potency): 54.6%
The estimate for compound 4 lay 4.6 percentage points below the measured number; measured number inside the range.
By their numbers in this assay, from the lowest: compounds 3, 2 and 4 (each within the scatter of the next, the first and the last beyond it); then compound 1.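

In this assay, methyl in place of hydrogen on the aromatic carbon ortho to a methyl group and para to a large group gives a number 6.8 percentage points higher from compound 2 to compound 4 (within the scatter). Among these compounds, this 3-methylphenyl to 3,4-dimethylphenyl pair is the first one-place comparison, and it shows that a second methyl at this position brings no change that can be told from the scatter. Nothing at hand explains this result. As far as these compounds go, whether a chlorine, a hydroxyl or an amine on this same carbon would give a step beyond the scatter remains open.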